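The compounds below may be only part of what the source reports. "The series", "measured", "known", "first", "only" and "open" are said of these compounds alone.

Measured compounds:
compound 1, `OC(CSc1[nH]cnc2ncnc1-2)CN1CCN(C(c2ccccc2)c2ccccc2)CC1`, 249%
compound 2, `CC(=O)Oc1ccccc1C(=O)OC(CSc1[nH]cnc2ncnc1-2)CN1CCN(C(c2ccc(F)cc2)c2ccc(F)cc2)CC1`, 34%

In a functional assay on muscle tissue (Mustela putorius furo) (a higher number here means a larger maximal response, a lower number a smaller maximal response), compound 1 gives 249%. In this assay, going by the values given here, compound 2 gives 34%, the lowest of the two numbers known; its nearest neighbour is compound 1, whose larger maximal response lies well beyond the scatter of the method. Compound 3, `O=S(=O)(O)OC(CSc1[nH]cnc2ncnc1-2)CN1CCN(C(c2ccc(F)cc2)c2ccc(F)cc2)CC1`, has not yet been measured. It differs from compound 2 in one place: sulfo in place of (2-acetoxyphenyl)carbonyl on an oxygen on a saturated carbon. Among the compounds with values here, no step between measured compounds exists with only this change, so the gap between compound 1 and compound 2 cannot be separated into the part from the ester and the part from the two fluorines. Compound 3 keeps the fluorinated diphenylmethyl piece of compound 2 but carries a much smaller group on the oxygen, and the expected step of a number 66 percentage points higher from compound 2 to compound 3 (beyond the scatter) in this assay is an increase beyond the scatter. For compound 3 the maximal response is estimated at 100%, within 30% to 220%.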

Compound 3, largest response reached (reported as maximum), in percent of the reference or control that the assay uses: 57%
Compound 3: the middle estimate sits 43 percentage points above what was measured; the range from low to high includes it.
By their numbers in this assay, from the lowest: compound 2; then compound 3; then compound 1.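

In this assay, this position now has its first single-change comparison: sulfo in place of (2-acetoxyphenyl)carbonyl on an oxygen on a saturated carbon gives a number 23 percentage points higher from compound 2 to compound 3 (beyond the scatter) in the maximal response. So the change is modest but real, even though a group of 12 heavy atoms with an aromatic ring leaves and a group of 4 heavy atoms with no ring enters. No measurement is available that explains this step.

Two groups on this oxygen cannot show whether size, ring loss or another difference drives the step, nor how a methyl or phosphono group would compare. The fluorinated compound with a free hydroxyl on this oxygen is also missing from those shown, so the contribution of the two fluorines remains unseparated from that of the oxygen substituent.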